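A few compounds are considered here, and "the series" means these few. Any claim that something is new, unique, unknown or untested is made for them only; others in the source may bear on it.

Measured in a functional assay on NIH3T3 cells (Mus musculus); on this read-out higher numbers stand for an effect only at larger amounts of compound and lower numbers for an effect already at smaller amounts:
- Compound 1 `Cn1cncc1C(OCc1ccc(C#N)cc1-c1cccc2ccccc12)c1ccc(C#N)nc1`: 46 nM
- Compound 2 `Cn1cncc1C(OCc1nc(N2CCC(O)CC2)c(C#N)cc1-c1cccc(Cl)c1)c1ccc(C#N)cc1`: 3.6 nM
- Compound 3 `Cn1cncc1C(OCc1ccc(C#N)nc1-c1ccc2ccccc2c1)c1ccc(C#N)cc1`: 7.4 nM

Compound 1 has the highest number of the three, so it needs the largest amount to show its effect. Compound 4 `Cn1cncc1C(OCc1ccc(C#N)cc1-c1cc(Cl)cc(Cl)c1)c1ccc(C#N)nc1` keeps the core of compound 1 but has 3,5-dichlorophenyl in place of naphthalen-1-yl on an aromatic carbon. Within the data shown here, no measured pair shows this change, so any forecast in this assay is uncertain. Compound 2 at 3.6 nM and compound 3 at 7.4 nM both sit lower, so a modest drop seems likelier than a rise. The expected step is a 1.8-fold lower number from compound 1 to compound 4 (0.26 log units; within the scatter), which may not clear the usual scatter. The estimate for compound 4 is 25 nM, with an expected range of 6 nM to 100 nM.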

Compound 4, half-maximal effective concentration: 3.5 nM
Estimate against measurement, compound 4: 7.1-fold (0.85 log units) above, and the stated range ends above it.
By their numbers in this assay, from the lowest: compounds 4 and 2 (each within the scatter of the next); then compound 3; then compound 1.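

In this assay, among these compounds, putting 3,5-dichlorophenyl in place of naphthalen-1-yl gives a large change (a 13-fold lower number from compound 1 to compound 4 (1.12 log units; beyond the scatter)), the first direct reading of a single change at this aromatic carbon. It shows that the group held here strongly affects the result, and that one ring carrying two chlorine atoms does far better on this core than the two-ring naphthalen-1-yl. Nothing given here explains why the step is so large. From the compounds shown here alone, it remains open whether both chlorine atoms are needed, and how unsubstituted phenyl or 3,5-dimethoxyphenyl would compare at this position.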